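Chloro added to the trifluoromethylphenyl urea arm

The source may report more compounds than this note shows. Statements on the series, on what has been measured and on what is new or still open speak of the compounds shown alone.

Working notes on a small set sharing one core. Going by the values given here, compound 1 `O=C(Nc1cccc(-n2cc(-c3ccncc3)c(-c3ccc(Cl)c(O)c3)n2)c1)Nc1cccc(C(F)(F)F)c1` gives 3540 nM in a functional assay on SF-539 cells (Homo sapiens) for inhibition, read by sulforhodamine B assay, with a stated time of 48 h (a lower number here means a stronger inhibitor of growth, a higher number a weaker inhibitor of growth), which is the highest of the two numbers so far; its nearest neighbour is compound 2 `COc1cc(-c2nn(-c3cccc(NC(=O)Nc4cccc(C(F)(F)F)c4)c3)cc2-c2ccncc2)ccc1Cl`, which in this assay gives 890 nM. Among the compounds with values here, the one measured step, a 4.0-fold lower number from compound 1 to compound 2 (0.60 log units; beyond the scatter), comes from a methyl in place of hydrogen on an oxygen on an aromatic ring, a change on the opposite side of the core from the urea.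

Compound 3 `O=C(Nc1cccc(-n2cc(-c3ccncc3)c(-c3ccc(Cl)c(O)c3)n2)c1)Nc1ccc(Cl)c(C(F)(F)F)c1` differs from compound 1 as follows: chloro in place of hydrogen on an aromatic carbon. Within the data shown here, no measured step touches this arm of the molecule, so the step from compound 1 to compound 2 gives no direct guide, only a sense that single small changes in this set can move the number modestly. With nothing to anchor direction, the expected step of a 1.4-fold lower number from compound 1 to compound 3 (0.15 log units; within the scatter) is taken as small, possibly within the scatter, in either direction. For compound 3 the estimated value in this assay is 2500 nM, with a range from 700 nM to 9000 nM.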

Compound 3, concentration for 50% growth inhibition: 782 nM
Compound 3: middle estimate off by 3.2-fold (0.50 log units), on the high side, and the stated range covers the measured number.
By their numbers in this assay, from the lowest: compounds 3 and 2 (each within the scatter of the next); then compound 1.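

In this assay, the urea arm responds to a very small change: a 4.5-fold lower number from compound 1 to compound 3 (0.66 log units; beyond the scatter) comes from a single chlorine atom on an aromatic carbon, ortho to a trifluoromethyl group and para to a large group. Going by these compounds alone, the only earlier step did not touch this arm, so this is the first sign that its aromatic ring can also carry a change that moves the number beyond the scatter, here towards a lower number. No measurement of any property accompanies these compounds, so the data offer no explanation for this step.

From the compounds shown here alone, it remains open whether other groups on the same carbon, such as fluoro, methyl or an amine, would move the number in the same direction, or by a similar amount, as chloro. Also open, going by these compounds, is whether this chloro and the methyl on the oxygen would add up in one molecule, as the two changes appear here only in separate compounds, each compared with compound 1 alone.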